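The source may report more compounds than this note shows. Statements on the series, on what has been measured and on what is new or still open speak of the compounds shown alone.

Measured so far:
Compound 2 `COc1ccc2nc(C)cc(OCC(=O)Nc3ccc(C)c(C)c3)c2c1`: 16.2 mL/min/kg
Compound 1 `CCCCc1ccc(NC(=O)COc2cc(C)nc3ccc(OC)cc23)cc1`: 16.3 mL/min/kg

In an ADME assay on liver (Homo sapiens) for metabolic stability, read by LC-MS, using S9 fraction, tested at 2 uM (on this read-out higher numbers stand for fast clearance and lower numbers for slow clearance), compound 2 gives 16.2 mL/min/kg, and compound 1 gives 16.3 mL/min/kg. The two numbers lie within the scatter of repeated measurements, so compound 2 stands level with compound 1 rather than apart from it. Compound 3 `CCCc1ccc(NC(=O)COc2cc(C)nc3ccc(OC)cc23)cc1` has not yet been measured. It keeps the shared core of compound 2 and differs from it in one place: 4-propylphenyl in place of 3,4-dimethylphenyl on an amide-type nitrogen. Among the measured compounds shown here, no measured pair shows a change of this kind, so nothing can be read from a step. What the data do show is that compound 1 and compound 2 carry different groups at this same place on the amide-type nitrogen and still give values within the scatter of each other. On that basis, the step of a 1.0-fold lower number from compound 2 to compound 3 (0.01 log units; within the scatter) is expected to show no size beyond the scatter, in neither direction. For compound 3 the estimate is 16 mL/min/kg, within a range from 9 mL/min/kg to 29 mL/min/kg.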

Compound 3, clearance in the liver assay: 12.7 mL/min/kg
The estimate for compound 3 lay 1.3-fold (0.10 log units) above the measured number, within the range that was stated.
By their numbers in the liver assay, from the lowest: compounds 3, 2 and 1 (each within the scatter of the next).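

Compound 3 now gives two single-place comparisons in the liver assay, and neither step leaves the scatter: a 1.3-fold lower number from compound 2 to compound 3 (0.11 log units; within the scatter), and a 1.3-fold lower number from compound 1 to compound 3 (0.11 log units; within the scatter), with hydrogen in place of methyl on a saturated chain carbon, three bonds along the chain from an aromatic carbon. A second read-out separates compounds that clearance does not: in a physicochemical assay for solubility, read by HPLC, measured as thermodynamic solubility, with a stated time of 24 h, at pH 4 (a lower number here means a less soluble compound, a higher number a more soluble compound), compound 2 gives 410000 nM and compound 3 gives 90000 nM. At this place on the amide-type nitrogen, 4-propylphenyl in place of 3,4-dimethylphenyl therefore leaves the liver assay within the scatter but lowers the number in the physicochemical assay: the measured solubility of compound 2, 410000 nM, and of compound 3, 90000 nM, a 4.6-fold lower number (0.66 log units; beyond the scatter)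

From the compounds shown here alone, whether an amine or a carboxylic acid on this phenyl ring would move clearance beyond the scatter remains open. So does which part of the swap, the propyl chain or the loss of the two methyl groups, accounts for the lower solubility.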